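Changing the Phenyl Group of Compound 2

The compounds below may be only part of what the source reports. "The series", "measured", "known", "first", "only" and "open" are said of these compounds alone.

In a functional assay for inhibition, with Homo sapiens as the target (a higher number here means weaker binding, a lower number tighter binding), compound 1 `N#Cc1ccc(C2OCC(C/C=C\CCC(=O)O)C(c3cccnc3)O2)cc1` gives 1290 nM, while compound 2 `CC(C)(Sc1ccccc1)C1OCC(C/C=C\CCC(=O)O)C(c2cccnc2)O1` gives 200 nM. Compound 2 therefore has the lower of the two numbers and is the tighter binder so far. Among the compounds with values here, only one measured step is available: a 6.5-fold lower number from compound 1 to compound 2 (0.81 log units; beyond the scatter). That step replaced a whole group on a saturated ring carbon.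

Compound 3 `COc1ccc(SC(C)(C)C2OCC(C/C=C\CCC(=O)O)C(c3cccnc3)O2)c([N+](=O)[O-])c1` keeps that carbon's group largely intact and changes only its far end: 4-methoxy-2-nitrophenyl in place of phenyl on a sulfur. In words, 4-methoxy-2-nitrophenyl stands in place of phenyl on a sulfur. The step to compound 2, a 6.5-fold lower number from compound 1 to compound 2 (0.81 log units; beyond the scatter), shows that a change in a group attached to the core can move the number beyond the scatter. However, no measured compound carries anything extra on this phenyl, so the direction of the new step cannot be read from the data. A small step towards a lower number is expected, though it may not clear the scatter. The estimate means a 1.5-fold lower number from compound 2 to compound 3 (0.19 log units; within the scatter). For compound 3 the expected value is 130 nM, with an estimated range of 35 nM to 500 nM.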

Compound 3, dissociation constant: 158 nM
Beside the measured number, compound 3's estimate is 1.2-fold (0.08 log units) below it; low and high end bracket the measured number.
By their numbers in this assay, from the lowest: compounds 3 and 2 (each within the scatter of the next); then compound 1.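

In this assay the switch from phenyl to 4-methoxy-2-nitrophenyl on a sulfur gives a 1.3-fold lower number from compound 2 to compound 3 (0.10 log units; within the scatter) and so compound 2 and compound 3 cannot be told apart in this assay. Within the data shown here, this is the first measured change at the far end of the group on the saturated ring carbon, and it is not a small one: 11 heavy atoms replace 6, and 3 hydrogen-bond acceptors stand where phenyl has 0, yet the number stays within the scatter. So, for this one pair, a much larger group on the sulfur leaves the reading indistinguishable, but no information is available on why the two numbers lie so close.

Since the methoxy and the nitro group enter together, the pair cannot show what either does alone, and 4-methoxyphenyl or 2-nitrophenyl on the sulfur could give quite different numbers from the pair of groups together. Going by these compounds, it also remains open whether a group of another kind on this phenyl, such as an amine or a carboxylic acid, would move the number beyond the scatter.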